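The source may hold more compounds than are shown below. What is called first, only, known or untested is meant among the compounds shown, and "the series" means these compounds.

Among the compounds with values here, compound 2 `Cc1nn(C)c(Sc2ccccc2)c1/C=N/OCc1ccc(C(=O)OC(C)(C)C)cc1` is one of only two compounds measured so far in a functional assay on SK-OV-3 cells (Homo sapiens) for cytotoxicity; on this read-out higher numbers stand for weaker inhibition and lower numbers for stronger inhibition. In this assay compound 2 gives 0.92 ug/mL, the lowest of the two numbers. Compound 1 `Cc1nn(C)c(N2CCCC2)c1/C=N/OCc1ccc(C(=O)OC(C)(C)C)cc1` carries a pyrrolidin-1-yl group where compound 2 carries phenylsulfanyl, and in this assay compound 1 gives 3.19 ug/mL. Within the data shown here, the single measured step, a 3.5-fold lower number from compound 1 to compound 2 (0.54 log units; beyond the scatter), is thus the exchange of a ring amine for a sulfur-linked phenyl ring, and it lowered the number beyond the scatter. Compound 3 `Cc1nn(C)c(N(C)C)c1/C=N/OCc1ccc(C(=O)OC(C)(C)C)cc1` moves back toward an amine: dimethylamino in place of phenylsulfanyl on an aromatic carbon. The step from compound 1 to compound 2 bears directly on this change, because a 3.5-fold lower number from compound 1 to compound 2 (0.54 log units; beyond the scatter) shows that the amine on this ring carbon went with a higher number than phenylsulfanyl; dimethylamino is a smaller, open-chain amine, so the number for compound 3 is expected to rise again, by a modest but real amount, landing near compound 1. For compound 3 the expected step is a 2.8-fold higher number from compound 2 to compound 3 (0.45 log units; beyond the scatter). Compound 3 is estimated at 2.6 ug/mL, with a range from 1 ug/mL to 6.5 ug/mL.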

Compound 3, half-maximal inhibitory concentration: 9.06 ug/mL
Compound 3: the middle estimate sits 3.5-fold (0.54 log units) below what was measured; the whole stated range lies below it.
By their numbers in this assay, from the lowest: compound 2; then compound 1; then compound 3.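

In this assay the exchange of phenylsulfanyl for dimethylamino gives a 9.8-fold higher number from compound 2 to compound 3 (0.99 log units; beyond the scatter) and so places this open-chain amine beyond compound 1 rather than close to it. Exchanging pyrrolidin-1-yl for dimethylamino gives a 2.8-fold higher number from compound 1 to compound 3 (0.45 log units; beyond the scatter) and this shows what the first pair could not: on this aromatic carbon the two amines are not interchangeable, so the kind of amine matters and not only whether an amine or phenylsulfanyl sits there. Across these three compounds the number rises from phenylsulfanyl through pyrrolidin-1-yl to dimethylamino, so the group with the fewest heavy atoms goes with the highest number, but nothing measured here explains this order.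

These compounds cannot separate the part played by the sulfur from that of the phenyl ring, a question that a phenoxy or benzyl group on the same carbon would address. Going by these compounds, it also remains open whether a larger ring amine, such as piperidin-1-yl or morpholin-4-yl, would fit the same order.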